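Amide nitrogen substituent and paw edema inhibition in a triazole series

The source may report more compounds than this note shows. Statements on the series, on what has been measured and on what is new or still open speak of the compounds shown alone.

Measured compounds, inhibition of paw edema in a functional assay on the whole organism for inhibition, with Rattus norvegicus as the target, read by paw edema, with stated times of 30 min and 4 h, at a dose of 0.28 mmol/kg by the oral route; on this read-out higher numbers stand for more inhibition at the one dose given (going by the name of the read-out) and lower numbers for less inhibition:
- compound 1 `COc1ccc(-n2nc(C(N)=O)nc2-c2cc(OC)c(OC)c(OC)c2)cc1`: 71%
- compound 2 `COc1ccc(NC(=O)c2nc(-c3cc(OC)c(OC)c(OC)c3)n(-c3ccc(OC)cc3)n2)cc1`: 63%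
- compound 3 `COc1ccc(-n2nc(C(=O)Nc3ccccc3OC)nc2-c2cc(OC)c(OC)c(OC)c2)cc1`: 24%

Compound 3 stands lowest of the three numbers in this assay. Its nearest neighbour is compound 2, a step of a number 39 percentage points lower from compound 2 to compound 3 (beyond the scatter); the furthest is compound 1, a step of a number 47 percentage points lower from compound 1 to compound 3 (beyond the scatter). The step of a number 8 percentage points lower from compound 1 to compound 2 (within the scatter) lies within the scatter, so the amide hydrogen and the 4-methoxyphenyl group give numbers that cannot be ordered.

Compound 4 `COc1ccc(-n2nc(C(=O)Nc3ccc(C)cc3)nc2-c2cc(OC)c(OC)c(OC)c2)cc1` is the next member. The change from compound 3 is 4-methylphenyl in place of 2-methoxyphenyl on an amide-type nitrogen. The step that bears on it most directly is a number 39 percentage points lower from compound 2 to compound 3 (beyond the scatter), which shows that an aryl group carrying its substituent as in 4-methoxyphenyl gives a much higher number than 2-methoxyphenyl. Going by the values given here, the 4-methylphenyl group of compound 4 has no measured counterpart, so the size of the return is uncertain. A rise of about a number 31 percentage points higher from compound 3 to compound 4 (beyond the scatter) is expected, bringing compound 4 near compound 2 but short of it. Compound 4 is therefore estimated at 55%, with a range from 32% to 75%.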

Compound 4, a percentage reported as inhibition, in the whole organism at one dose (the size of the read-out at that dose, not a potency): 58%
Compound 4: the middle estimate sits 3 percentage points below what was measured; low and high end bracket the measured number.
By their numbers in this assay, from the lowest: compound 3; then compounds 4, 2 and 1 (each within the scatter of the next, the first and the last beyond it).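

The step to 4-methylphenyl on the amide-type nitrogen in this assay, a number 34 percentage points higher from compound 3 to compound 4 (beyond the scatter), shows that a second aryl group stands clear of 2-methoxyphenyl, so the low number of compound 3 is not common to the three aryl amides shown. Methyl in place of methoxy on an aromatic carbon gives a number 5 percentage points lower from compound 2 to compound 4 (within the scatter), so these two groups cannot be ordered, while a number 13 percentage points lower from compound 1 to compound 4 (beyond the scatter) places the amide hydrogen above an aryl group for the first time, although the corresponding step to 4-methoxyphenyl could not be read that way. No measurement available here explains these differences.

Going by these compounds, it remains open whether the low number goes with the methoxy group or with its place on the ring, which 2-methylphenyl and 4-methylphenyl as a pair could separate. On these data alone, the effect of a benzyl group or a longer alkyl chain on the same nitrogen also remains open.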